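Swapping the aryl group of a thiosemicarbazone

The compounds below may be only part of what the source reports. "The series", "measured", "known", "first", "only" and "open" are said of these compounds alone.

Compound 2 `CC1=CC[C@H](C(C)(C)NC(=S)N/N=C/c2ccc(F)cc2)CC1` is one of two measured thiosemicarbazones built on the shared core. In a functional assay on NCI/ADR-RES cells (Homo sapiens) for inhibition, read by sulforhodamine B assay, with a stated time of 48 h (a higher number here means a weaker inhibitor of growth, a lower number a stronger inhibitor of growth), compound 2 gives only a limit, > 100000 nM. Compound 1 `CC1=CC[C@H](C(C)(C)NC(=S)N/N=C/c2ccccc2O)CC1` gives 10900 nM in this assay. Within the data shown here, the single measured step, an at least 9.1-fold higher number from compound 1 to compound 2 (0.96 log units; beyond the scatter), is at least modest and rests on (the limit of > 100000 nM in this assay, at which 1 of the 2 values shown sits), so compound 2 stands at the weak end of what has been measured. Compound 3 `CC1=CC[C@H](C(C)(C)NC(=S)N/N=C/c2ccccc2Cl)CC1` differs from compound 2 by 2-chlorophenyl in place of 4-fluorophenyl on a carbon with a double bond to nitrogen. Among the measured compounds shown here, no measured step covers this exchange directly; the only comparison available, from compound 1 to compound 2, shows that changing the aryl group can move the read-out beyond the scatter. With compound 2 known only as a limit, the step from compound 2 to compound 3 is expected to be an at least 1.6-fold lower number from compound 2 to compound 3 (0.22 log units; that floor lies within the scatter). For compound 3 the estimate in this assay is 60000 nM, within 15000 nM to 200000 nM.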

Compound 3, concentration for total growth inhibition: > 100000 nM
Compound 3: only a limit was reported; the forecaster's own chance of this, stated with the estimate: 45%; middle value at least 1.6-fold (0.22 log units) away from the limit.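

Chloro in place of hydroxy on an aromatic carbon gives an at least 9.1-fold higher number from compound 1 to compound 3 (0.96 log units; beyond the scatter) in this assay and so shows that the loss seen with 4-fluorophenyl is not confined to that group, since 2-chlorophenyl on the same carbon with a double bond to nitrogen also ends in a limit. The step between compound 2 and compound 3 cannot be read, so these two aryl groups cannot be put in order. Of the three aryl groups, only 2-hydroxyphenyl in compound 1 gives a number and not a limit in this assay: the limit of > 100000 nM in this assay, at which 2 of the 3 values shown sit.

The compounds shown leave open whether an amine or a carboxylic acid in place of the chloro on that aromatic carbon would give a number rather than a limit. They also leave open what compound 2 and compound 3 would read beyond their limits.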